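From benzyl to 3-iodophenyl on the amide nitrogen

The compounds below may be only part of what the source reports. "The series", "measured", "known", "first", "only" and "open" are said of these compounds alone.

Measured so far in a functional assay on SK-OV-3 cells (Homo sapiens) for antiproliferative activity, read by MTT assay, with a stated time of 72 h; a lower number here means a stronger inhibitor, a higher number a weaker inhibitor
- Compound 1 (`O=C(CCc1cccc2c1B(O)OC2)NCc1ccccc1`) gives > 100000 nM as a limit of the assay
- Compound 2 (`C#Cc1ccc(NC(=O)CCc2cccc3c2B(O)OC3)cc1`) gives 6300 nM
- Compound 3 (`CC(C)(C)OC(=O)NCc1ccc(NC(=O)CCc2cccc3c2B(O)OC3)cc1`) gives 2000 nM

Compound 1 stands at the limit of > 100000 nM in this assay, at which 1 of the 3 values shown sits, and so offers a limit and no number. Compound 4 (`O=C(CCc1cccc2c1B(O)OC2)Nc1cccc(I)c1`) keeps the core of compound 1 and changes one group, with 3-iodophenyl in place of benzyl on an amide-type nitrogen, counted as 3-iodophenyl in place of benzyl on an amide-type nitrogen in full. For the measured compounds named here, no measured step covers this exchange directly. The nearest evidence comes from compound 2 and compound 3, which also carry a substituted phenyl on that nitrogen. Going by the values given here, the one measured step is a 3.2-fold lower number from compound 2 to compound 3 (0.50 log units; beyond the scatter) and it is modest, though beyond the scatter. On that step, compound 4 is expected to land near compound 2 with 6300 nM and compound 3 with 2000 nM in the same range. The expected change is estimated as an at least 16-fold lower number from compound 1 to compound 4 (1.22 log units; beyond the scatter) in this assay and is large, toward a lower number. For compound 4 the expected value is 6000 nM (estimated range 1800 nM to 25000 nM).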

Compound 4, half-maximal inhibitory concentration: 630 nM
Estimate against measurement, compound 4: 9.5-fold (0.98 log units) above; the whole stated range lies above it.
By their numbers in this assay, from the lowest: compound 4; then compound 3; then compound 2. At a limit, above all of these: compound 1.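

In this assay, for the compounds shown here, 3-iodophenyl in place of benzyl on the amide-type nitrogen gives an at least 150-fold lower number from compound 1 to compound 4 (2.20 log units; beyond the scatter), the first step that tests this position directly while the core of compound 1 stays the same. Both groups have the same heavy-atom count and one six-membered aromatic ring of carbon only, so this large step comes with no change in either count, though the entering group does bring iodine. The value of compound 1 is a limit and not a number, so the step has a minimum size and no exact one: the limit of > 100000 nM in this assay, at which 1 of the 4 values shown sits.

The compounds shown leave open whether the change follows the iodine or the phenyl on the amide-type nitrogen. A plain phenyl or a 3-iodobenzyl group at this position would separate the two.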